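Changing the Group on the Ring Nitrogen

The source may hold more compounds than are shown below. What is called first, only, known or untested is meant among the compounds shown, and "the series" means these compounds.

The measured compounds, all tested in a functional assay on A549 cells (Homo sapiens) for cytotoxicity, read by MTT assay, with a stated time of 72 h; a lower number here means a stronger inhibitor, a higher number a weaker inhibitor:
compound 1 `Cc1cc(=O)n(-c2ccccc2OC(F)(F)F)nc1C(=O)Nc1ccc(Oc2ncnc3ccsc23)c(F)c1` gives 5720 nM
compound 2 `Cc1cc(=O)n(-c2ccc(Br)cc2F)nc1C(=O)Nc1ccc(Oc2ncnc3sccc23)c(F)c1` gives 11500 nM
compound 3 `O=C(Nc1ccc(Oc2ncnc3ccsc23)c(F)c1)c1nn(-c2ccc(F)c(Cl)c2)ccc1=O` gives 9650 nM

Compound 3 has the second highest of these three numbers. The value of compound 2 lies closest to it and within the usual scatter, and the value of compound 1, the furthest away, lies within that scatter as well, so the three compounds cannot be told apart on this assay. Compound 4 `Cc1ccc(-n2ccc(=O)c(C(=O)Nc3ccc(Oc4ncnc5ccsc45)c(F)c3)n2)cc1` has not been measured. It differs from compound 3 in one place: 4-methylphenyl in place of 3-chloro-4-fluorophenyl on an aromatic nitrogen. For the measured compounds named here, there is no measured step for this change to lean on. The three measured compounds carry three different groups at this position and yet give values that all lie within the scatter of each other, and nothing here suggests that the change should move the number beyond the scatter in either direction in this assay. The expected step is a 1.1-fold lower number from compound 3 to compound 4 (0.06 log units; within the scatter). The estimate for compound 4 is 8500 nM, with a range from 3000 nM to 25000 nM.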

Compound 4, half-maximal inhibitory concentration: 11600 nM
The estimate for compound 4 lay 1.4-fold (0.14 log units) below the measured number; the measured number falls inside the stated range.
By their numbers in this assay, from the lowest: compounds 1, 3, 2 and 4 (each within the scatter of the next, the first and the last beyond it).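

For the compounds shown here, this is the first direct reading of this position with the rest of the molecule held the same: 4-methylphenyl in place of 3-chloro-4-fluorophenyl on the aromatic nitrogen gives a 1.2-fold higher number from compound 3 to compound 4 (0.08 log units; within the scatter) in this assay, which lies within the scatter. The group that leaves carries a fluorine and a chlorine and the group that enters carries only carbon, yet this assay cannot tell the two compounds apart. Nothing available explains this result.

From the compounds shown here alone, all four compounds carry a substituted phenyl ring on this nitrogen, so a different kind of group remains untested in this comparison, such as an amine or a carboxylic acid on that ring, or a longer chain in its place. Going by these compounds, whether any such group would move the number beyond the scatter stays open.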